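This account rests on a few compounds, and the source may have more. Where it says the series, first, only, none or still open, it means among the compounds named here.

In an ADME assay on HeLa cells (Homo sapiens) for cytotoxicity (on this read-out higher numbers stand for lower toxicity in this test and lower numbers for higher toxicity in this test), compound 1 (`CCN(CC)CN1C(=O)/C(=N/NC(=S)Nc2ccc(OC)cc2)c2ccccc21`) shows > 100000 nM as a limit of the assay. Among the compounds with values here, compound 2 (`CCN(CC)CN1C(=O)/C(=N/NC(=S)Nc2ccccc2)c2ccccc21`) gives 10800 nM in this assay and is the only compound with a true number so far. Compound 3 (`CCN(CC)CN1C(=O)/C(=N/NC(N)=S)c2ccccc21`) follows from compound 2 through hydrogen in place of phenyl on an amide-type nitrogen with hydrogen in place of phenyl on an amide-type nitrogen. Within the data shown here, the only measured step bearing on this is an at least 9.2-fold lower number from compound 1 to compound 2 (0.96 log units; beyond the scatter) and it involves a substituent on that phenyl, so a moderate move toward higher numbers is expected. The expected step is a 3.2-fold higher number from compound 2 to compound 3 (0.51 log units; beyond the scatter) in this estimate. Compound 3 is estimated at 35000 nM with an expected range from 9000 nM to 100000 nM in this assay.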

Compound 3, half-maximal cytotoxic concentration: > 100000 nM
Compound 3: a limit, no number; the forecaster's own chance of this, stated with the estimate: 20%; middle value at least 2.8-fold (0.45 log units) from the limit.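

In this assay, replacing the whole phenyl with hydrogen on the amide-type nitrogen gives an at least 9.2-fold higher number from compound 2 to compound 3 (0.96 log units; beyond the scatter), whereas the earlier step had only changed a substituent on that phenyl. Among these three compounds, only compound 2, with the unsubstituted phenyl, gives a true number, so both the 4-methoxyphenyl and hydrogen at this position go with higher readings. The step between compound 1 and compound 3 cannot be read because both values are limits: the limit of > 100000 nM in this assay, at which 2 of the 3 values shown sit.

On these data alone, the true values behind those limits remain open. So does whether a methyl, a benzyl or a 4-chlorophenyl on this nitrogen would give a measurable number.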